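The compounds below may be only part of what the source reports. "The series", "measured", "known", "first", "only" and "open" are said of these compounds alone.

In an ADME assay on HepG2 cells (Homo sapiens) for cytotoxicity, read by MTT assay (on this read-out higher numbers stand for weaker inhibition and lower numbers for stronger inhibition), compound 1 (`Fc1ccc(-c2nc(C(Cl)(Cl)Cl)nc3ccccc23)cc1`) gives > 125000 nM, which is a limit of the assay. Compound 2 (`Clc1ccc(-c2nc(C(Cl)(Cl)Cl)nc3ccccc23)cc1`) gives > 125000 nM, again a limit. Compound 3 (`ClC(Cl)(Cl)c1nc(-c2ccco2)c2ccccc2n1`) gives > 125000 nM, also a limit and not a number. Compound 3 therefore has no exact place on the scale and stands with the other two: the limit of > 125000 nM in this assay, at which 3 of the 3 values shown sit.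

Compound 4 (`Cc1ccc(-c2nc(C(Cl)(Cl)Cl)nc3ccccc23)s1`) differs from compound 3 at one place on the shared core: 5-methylthiophen-2-yl in place of furan-2-yl on an aromatic carbon. In words, 5-methylthiophen-2-yl stands in place of furan-2-yl on an aromatic carbon.

The closest measured changes are at this same place: a step that the two limits leave unreadable from compound 1 to compound 3 and a step that the two limits leave unreadable from compound 2 to compound 3. The remaining comparison, chloro in place of fluoro, gives a step that the two limits leave unreadable from compound 1 to compound 2. None of these steps has a readable size, so they offer no measured direction for the new exchange. Still, all three groups tried at this place left this assay at its limit, and compound 4 is expected to stay close to it. The expected size is a number no higher from compound 3 to compound 4 (the limit leaves the size open), which means no expected change beyond the scatter. For compound 4 the estimated value is 125000 nM, with an expected range from 50000 nM to 250000 nM.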

Compound 4, half-maximal inhibitory concentration: 25000 nM
The estimate for compound 4 lay 5.0-fold (0.70 log units) above the measured number; the whole stated range lies above it.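

In this assay, this place on the shared core now gives a step that can be read, where the steps among compound 1, compound 2 and compound 3 could not be: an at least 5.0-fold lower number from compound 3 to compound 4 (0.69 log units; beyond the scatter). Measured against the two phenyl-bearing compounds, the same group gives an at least 5.0-fold lower number from compound 2 to compound 4 (0.69 log units; beyond the scatter) and an at least 5.0-fold lower number from compound 1 to compound 4 (0.69 log units; beyond the scatter). The lower number means stronger inhibition, so the group at this place can bring cytotoxicity into the measurable range, and 5-methylthiophen-2-yl is the only group shown that leaves the limit: the limit of > 125000 nM in this assay, at which 3 of the 4 values shown sit.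

The compounds shown do not separate the sulfur ring from its methyl group, as 5-methylthiophen-2-yl differs from furan-2-yl in both, and a plain thiophen-2-yl or a 5-methylfuran-2-yl at this place would be needed to tell them apart. Also open, on these data alone, is whether the step holds with a different group in place of the trichloromethyl group, such as a methyl group or an amine, and how far the number would fall with a longer chain on the thiophene ring.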